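This account rests on a few compounds, and the source may have more. Where it says the series, first, only, none or still open, it means among the compounds named here.

Three close relatives of one scaffold have been measured in a functional assay on HeLa cells (Homo sapiens) for antiproliferative activity, read by CCK-8 assay, with a stated time of 72 h, tested at 2 uM; a lower number here means a weaker effect, a higher number a stronger effect of the compound at the concentration tested. Compound 1 `Nc1ccccc1NC(=O)c1ccc(CSC(=S)N2CCN(c3ccc(Cl)cc3)CC2)cc1` gives 51.2%, compound 2 `COc1ccc(N2CCN(C(=S)SCc3ccc(C(=O)Nc4ccccc4N)cc3)CC2)cc1` gives 39.4%, and compound 3 `Cc1ccc(N2CCN(C(=S)SCc3ccc(C(=O)Nc4ccccc4N)cc3)CC2)cc1` gives 25.3%. Compound 3 therefore stands lowest of the three: the step of a number 25.9 percentage points lower from compound 1 to compound 3 (beyond the scatter) and the step of a number 14.1 percentage points lower from compound 2 to compound 3 (beyond the scatter) both lie beyond the scatter, as does the step of a number 11.8 percentage points lower from compound 1 to compound 2 (beyond the scatter) between the two stronger compounds.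

The unmeasured compound 4 `Nc1ccccc1NC(=O)c1ccc(CSC(=S)N2CCN(c3ccccc3F)CC2)cc1` differs from compound 3 in one place: 2-fluorophenyl in place of 4-methylphenyl on an amine nitrogen in a ring. None of the three measured steps repeats this change. All of them exchange chloro, methoxy and methyl with one another, and a 2-fluorophenyl appears in none of them. The nearest guide is the step of a number 25.9 percentage points lower from compound 1 to compound 3 (beyond the scatter), in which methyl in place of a halogen lowered the number; read backwards, from methyl to a halogen, that step points upward, but the halogen here is fluorine rather than chloro and stands on a different carbon of the phenyl ring, so the size is uncertain. Compound 4 is therefore expected to give 40%, within 22% to 58%, which means an expected upward step of a number 14.7 percentage points higher from compound 3 to compound 4 (beyond the scatter) from compound 3.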

Compound 4, a percentage reported as inhibition, at one concentration (the size of the read-out at that concentration, not a potency): 17.5%
Compound 4: middle estimate off by 22.5 percentage points, on the high side; measured number outside the range, below it.
By their numbers in this assay, from the lowest: compounds 4 and 3 (each within the scatter of the next); then compound 2; then compound 1.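

In this assay, 2-fluorophenyl on the amine nitrogen in a ring gives a number 7.8 percentage points lower from compound 3 to compound 4 (within the scatter), so compound 4 cannot be told apart from compound 3, and a halogen on this phenyl ring is clearly not enough on its own to bring the higher number seen with the 4-chlorophenyl of compound 1. Setting the same group against the other two gives a number 21.9 percentage points lower from compound 2 to compound 4 (beyond the scatter) and a number 33.7 percentage points lower from compound 1 to compound 4 (beyond the scatter), the second being the largest step in the series so far, which shows how much the read-out at this position depends on exactly what the phenyl ring carries and where. No measurement at hand explains these differences.

Compound 4 differs from compound 1 in both the halogen and the carbon that bears it, so the compounds shown do not tell which of the two counts for more. A 4-fluorophenyl or a 2-chlorophenyl on the same nitrogen would separate the two, and an unsubstituted phenyl would give a reference against which every group here could be read.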